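Methoxy for methylsulfanyl on the benzylamine ring

The compounds below may be only part of what the source reports. "The series", "measured", "known", "first", "only" and "open" are said of these compounds alone.

Compound 1 `CSc1ccc(CNc2nc(SC)nc3ncccc23)cc1` is the lowest of the two numbered values: in a functional assay on HTB-54 cells (Homo sapiens) for cytotoxicity, read by MTT assay, with a stated time of 72 h (a lower number here means a stronger inhibitor of growth, a higher number a weaker inhibitor of growth), compound 1 gives 14800 nM. Compound 2 `COc1ccc(CNc2nc([SeH])nc3ccccc23)cc1` in this assay gives 60900 nM. Compound 3 `CSc1ccc(CNc2nc([SeH])nc3ccccc23)cc1` in this assay reaches only a limit of the assay, > 100000 nM; one of the three results sits at the limit of > 100000 nM in this assay, at which 1 of the 3 values shown sits.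

Among the measured compounds shown here, the one measured step of the change in hand runs from compound 3 to compound 2. Its structural content is methoxy in place of methylsulfanyl on an aromatic carbon, and in this assay it reads an at least 1.6-fold lower number from compound 3 to compound 2 (0.21 log units; that floor lies within the scatter). How the core of compound 1 differs from the core of compound 3 is not broken down here.

Compound 4 `COc1ccc(CNc2nc(SC)nc3ncccc23)cc1` is not yet measured. Relative to compound 1 it carries methoxy in place of methylsulfanyl on an aromatic carbon, the same change, at the same place, as from compound 3 to compound 2.

For compound 4 the step from compound 1 is expected to be a 1.5-fold lower number from compound 1 to compound 4 (0.17 log units; within the scatter), resting on the measured step from compound 3 to compound 2, an at least 1.6-fold lower number from compound 3 to compound 2 (0.21 log units; that floor lies within the scatter), whose floor lies within the scatter. Compound 4 is therefore estimated at 10000 nM in this assay, with a range from 4000 nM to 30000 nM.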

Compound 4, concentration for total growth inhibition: > 100000 nM
Compound 4 gave a limit, no number; the forecaster's own chance of this, stated with the estimate: 3%; middle value at least 10-fold (1.00 log units) away from the limit.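

Compound 4 gives > 100000 nM in this assay, a limit of the assay and not a number. Going by these compounds, the change of methylsulfanyl to methoxy reads an at least 6.7-fold higher number from compound 1 to compound 4 (0.82 log units; beyond the scatter), which shows that the result on one core does not carry over to the other in this pair: the same change on two cores in this assay, an at least 1.6-fold lower number (0.21 log units; that floor lies within the scatter) from compound 3 to compound 2 and an at least 6.7-fold higher number (0.82 log units; beyond the scatter) from compound 1 to compound 4, at least 11-fold (1.04 log units) apart, beyond the scatter of two such steps Both steps rest on a limit, so their exact sizes stay unknown, and two cores do not show which difference between the core of compound 1 and the core of compound 3 goes with the different outcome, nor how the change would read on any further core.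

Open, on these data alone, is whether methylsulfanyl itself is what keeps compound 1 below the limit on its core, or whether another group on that aromatic carbon, such as an amine, a carboxylic acid or a longer chain, would also give a measurable value. The compounds shown also leave open how the same change reads on cores other than these two.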